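From Amide-Type Nitrogen to Carbonyl: Estimating Compound 3

The source may hold more compounds than are shown below. What is called first, only, known or untested is meant among the compounds shown, and "the series" means these compounds.

Compound 2 `COc1cc(Cl)cc(-c2nn(-c3cccc(NC(=O)Nc4cccc(C(F)(F)F)c4)c3)cc2-c2ccncc2)c1` was tested in a functional assay on SK-MEL-2 cells (Homo sapiens) for inhibition, read by sulforhodamine B assay, with a stated time of 48 h, tested at 10 uM (a higher number here means a weaker effect of the compound at the concentration tested, a lower number a stronger effect), where compound 2 gives -36.7%. Compound 1 `COc1cc(Cl)cc(-c2nn(-c3cccc(NC(=O)Nc4ccc(Cl)c(Cl)c4)c3)cc2-c2ccncc2)c1` gives -32.1% in this assay. Going by the values given here, the only measured step, a number 4.6 percentage points lower from compound 1 to compound 2 (within the scatter), leaves compound 2 with the lowest of the two numbers, but since that step is within the scatter, the two compounds cannot be told apart on these data. Compound 3 `COc1cc(Cl)cc(-c2nn(-c3cccc(NC(=O)c4cccc(C(F)(F)F)c4)c3)cc2-c2ccncc2)c1` has not yet been measured; it differs from compound 2 by 3-(trifluoromethyl)phenyl in place of (3-(trifluoromethyl)phenyl)amino on a carbonyl carbon. Among the compounds with values here, no measured step touches a carbonyl carbon: the one known step exchanged one ring for another on an amide-type nitrogen and was too small to count. There is thus no measured basis for expecting a step in either direction in this assay, and the range must stay wide. The expected value for compound 3 is therefore -25%, with a range from -65% to 20%. This corresponds to an expected step of a number 11.7 percentage points higher from compound 2 to compound 3 (beyond the scatter).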

Compound 3, a percentage reported as activity, at one concentration (the size of the read-out at that concentration, not a potency): 56.4%
Compound 3: the middle estimate sits 81.4 percentage points below what was measured; measured number outside the range, above it.
By their numbers in this assay, from the lowest: compounds 2 and 1 (each within the scatter of the next); then compound 3.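

In this assay, putting 3-(trifluoromethyl)phenyl in place of (3-(trifluoromethyl)phenyl)amino on the carbonyl carbon gives a number 93.1 percentage points higher from compound 2 to compound 3 (beyond the scatter), and the same kind of change starting from (3,4-dichlorophenyl)amino gives a number 88.5 percentage points higher from compound 1 to compound 3 (beyond the scatter). Exchanging one ring for another on the amide-type nitrogen had left the numbers within the scatter, whereas losing that nitrogen, along with its hydrogen-bond donor, goes with a large weakening of the effect at the concentration tested. No available measurement explains why this change matters so much.

The compounds shown cannot separate the part played by the nitrogen from that of its hydrogen. A methylene group in that place, or a methylamino link, would help to tell the two apart, and 3,4-dichlorophenyl directly on the carbonyl carbon would show whether the ring still makes little difference there.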